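Turning the double bond of compound 3 from E to Z

A few compounds are considered here, and "the series" means these few. Any claim that something is new, unique, unknown or untested is made for them only; others in the source may bear on it.

Values in a functional assay on HT-29 cells (Homo sapiens) for inhibition (on this read-out higher numbers stand for weaker inhibition and lower numbers for stronger inhibition), are as follows:
- Compound 1 `CC(=O)Oc1ccc(/C=C/c2ccc3ccccc3c2)cc1` gives > 5000 nM (a limit)
- Compound 2 `Cc1ccc(/C=C\c2ccc3ccccc3c2)cc1` gives > 5000 nM (a limit)
- Compound 3 `FC(F)(F)c1ccc(/C=C/c2ccc3ccccc3c2)cc1` gives > 5000 nM (a limit)

Compound 3 stands at the limit of > 5000 nM in this assay, at which 3 of the 3 values shown sit, and so offers only a limit, not a number. Compound 4 `FC(F)(F)c1ccc(/C=C\c2ccc3ccccc3c2)cc1` differs from compound 3 in one respect: the two compounds have the same atoms and bonds and differ only in configuration as drawn: 1 of 1 stereo elements differ; a double bond is drawn E in compound 3 and Z in compound 4 and nothing leaves or enters. Within the data shown here, the one measured step, a step that the two limits leave unreadable from compound 1 to compound 3, gives no size to carry over. Compound 2, also drawn Z, gives > 5000 nM and this too is a limit of the assay. No step beyond the scatter is therefore expected in this assay, and another limit is the likeliest result. The expected change is a step that the limit leaves unreadable from compound 3 to compound 4 and no more. Compound 4 is estimated at 6000 nM with an expected range from 1500 nM to 20000 nM as its span.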

Compound 4, half-maximal inhibitory concentration: > 5000 nM
Compound 4: only a limit was reported; the forecaster's own chance of this, stated with the estimate: 80%; the middle value is on the limit's open side.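

In this assay compound 4 gives > 5000 nM, which is a limit. Among these compounds, no step to it can be read from compound 2 or compound 3, whose values are also limits. The compounds shown leave open whether the double bond's configuration or the swap of methyl for trifluoromethyl alters inhibition at all.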